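A Halogenated Aryl Amide Replaces the tert-Butyl Group

The compounds below may be only part of what the source reports. "The series", "measured", "known", "first", "only" and "open" are said of these compounds alone.

Compound 1 `CCOC(=O)c1sc(-c2cccc(NC(=O)c3ccc(C(C)(C)C)cc3)c2)nc1Nc1ccc(N2CCN(C)CC2)cc1`: 4.22%
Compound 2 `CCOC(=O)c1sc(-c2cccc(NC(=O)c3ccc(F)c(Cl)c3)c2)nc1Nc1ccc(N2CCN(C)CC2)cc1`: 20.7%
Compound 3 `CN1CCN(c2ccc(Nc3nc(-c4cccc(NC(=O)c5ccc(C(C)(C)C)cc5)c4)sc3C(N)=O)cc2)CC1`: 12.1%

In a functional assay on Raji cells (Homo sapiens) for antiproliferative activity, read by CCK-8 assay, with a stated time of 72 h, tested at 40 uM (a higher number here means more inhibition at the concentration tested (going by the name of the read-out), a lower number less inhibition), compound 3 gives 12.1%, the second highest of the three numbers. Its nearest neighbour is compound 1, which in this assay gives 4.22%, and the gap between them, a number 7.9 percentage points higher from compound 1 to compound 3 (within the scatter), lies within the scatter; the gap to compound 2 also lies within the scatter, so none of the three can be ordered with confidence.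

Compound 4 `CN1CCN(c2ccc(Nc3nc(-c4cccc(NC(=O)c5ccc(F)c(Cl)c5)c4)sc3C(N)=O)cc2)CC1` has not yet been measured. It differs from compound 3 in one place: 3-chloro-4-fluorophenyl in place of 4-(tert-butyl)phenyl on a carbonyl carbon.

Going by the values given here, one measured step bears directly on this change. Between compound 1 and compound 2 the same aryl swap was made on the ethyl ester partner, and the step of a number 16.5 percentage points higher from compound 1 to compound 2 (beyond the scatter) was beyond the scatter. Since compound 3 and compound 4 differ in exactly the same way, a step of similar size and direction is expected in this assay, namely a number 15.9 percentage points higher from compound 3 to compound 4 (beyond the scatter).

Compound 4 is therefore estimated to give 28% in this assay, with a plausible range from 15% to 42%, because the prior step a number 16.5 percentage points higher from compound 1 to compound 2 (beyond the scatter) rested on a single pair only.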

Compound 4, a percentage reported as inhibition, at one concentration (the size of the read-out at that concentration, not a potency): 94.4%
Beside the measured number, compound 4's estimate is 66.4 percentage points below it, outside the stated range (above it).
By their numbers in this assay, from the lowest: compounds 1, 3 and 2 (each within the scatter of the next, the first and the last beyond it); then compound 4.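

In this assay, the result shows that the effect of placing 3-chloro-4-fluorophenyl on this carbonyl carbon, in place of 4-(tert-butyl)phenyl, depends heavily on the rest of the molecule. With amino on the other carbonyl, the step is a number 82.3 percentage points higher from compound 3 to compound 4 (beyond the scatter), far larger than the step seen with ethoxy there: the same change on two cores in this assay, a number 16.5 percentage points higher (beyond the scatter) from compound 1 to compound 2 and a number 82.3 percentage points higher (beyond the scatter) from compound 3 to compound 4, 65.8 percentage points apart, beyond the scatter of two such steps

The reverse reading tells the same story, since amino in place of ethoxy makes little measurable difference with the tert-butyl group present, yet with 3-chloro-4-fluorophenyl present the step is a number 73.7 percentage points higher from compound 2 to compound 4 (beyond the scatter), which is not what the earlier pair suggested: the same change on two cores in this assay, a number 7.9 percentage points higher (within the scatter) from compound 1 to compound 3 and a number 73.7 percentage points higher (beyond the scatter) from compound 2 to compound 4, 65.8 percentage points apart, beyond the scatter of two such steps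

So the two changes do not simply add up, and among these four compounds the high inhibition appears only where both occur together. As far as these compounds go, it remains open whether chlorine or fluorine matters more, which 3-chlorophenyl and 4-fluorophenyl amides could help to separate, and whether a methylamino group or a carboxylic acid in place of amino would keep the effect. From the compounds shown here alone, each number also reflects a single concentration, so the potency of compound 4 remains unknown.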